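The source may report more compounds than this note shows. Statements on the series, on what has been measured and on what is new or still open speak of the compounds shown alone.

Measured compounds in a functional assay on MCF7 cells (Homo sapiens) for cytotoxicity, read by MTT assay, with a stated time of 72 h; a lower number here means a stronger inhibitor, a higher number a weaker inhibitor:
compound 1, `O=C(NCc1ccc(F)cc1)c1nc(Br)c2cccnc2c1NCc1ccccc1`: "not determined" (no result reported)
compound 2, `CNCCCNc1c(C(=O)NCc2ccc(F)cc2)nc(Br)c2cccnc12`: > 10000 nM, which is a limit of the assay, not a number
compound 3, `CN(C)CCCNc1c(C(=O)NCc2ccc(F)cc2)nc(Br)c2cccnc12`: 7000 nM

Going by the values given here, compound 3 holds the only plain number in this assay. Compound 2 reaches only (the limit of > 10000 nM in this assay, at which 1 of the 3 values shown sits). Compound 1 has no result in this assay. Among the compounds with values here, the one measured step, an at least 1.4-fold lower number from compound 2 to compound 3 (0.15 log units; that floor lies within the scatter), runs from a limit, so its true size is unknown beyond its floor, and that floor lies within the scatter.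

Compound 4, `Nc1cccc(Nc2c(C(=O)NCc3ccc(F)cc3)nc(Br)c3cccnc23)c1`, differs from compound 3 as follows: 3-aminophenyl in place of 3-(dimethylamino)propyl on a nitrogen on an aromatic ring. Within the data shown here, no measured step bears on this change: the single step concerns a methyl in place of hydrogen on an amine nitrogen, while here 3-aminophenyl replaces 3-(dimethylamino)propyl on a nitrogen on an aromatic ring. There is therefore no basis for expecting a step beyond the scatter in either direction, and the estimate is held close to compound 3 with a wide range. Compound 4 is expected to give 6000 nM, with a range from 1000 nM to 30000 nM. The step this estimate means is a 1.2-fold lower number from compound 3 to compound 4 (0.07 log units; within the scatter), and it is an expectation only.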

Compound 4, half-maximal inhibitory concentration: 8000 nM
Beside the measured number, compound 4's estimate is 1.3-fold (0.12 log units) below it, and the stated range covers the measured number.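

In this assay, 3-aminophenyl in place of 3-(dimethylamino)propyl on this nitrogen gives a 1.1-fold higher number from compound 3 to compound 4 (0.06 log units; within the scatter), so compound 3 and compound 4 cannot be told apart, although one carries an open chain and the other a six-membered aromatic ring of carbon only. On these data alone, measured against the 3-(methylamino)propyl chain, the same position gives an at least 1.2-fold lower number from compound 2 to compound 4 (0.09 log units; that floor lies within the scatter), and the true size of this step is unknown beyond its floor. Compound 2 stands at a limit of the assay, not a number: the limit of > 10000 nM in this assay, at which 1 of the 4 values shown sits.

As far as these compounds go, it remains open whether any group on this nitrogen can move the number beyond the scatter, for example a carboxylic acid or a longer chain ending in an amine. From the compounds shown here alone, whether a plain phenyl, without the amine, would read the same also stays open.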